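Phenyl ether in place of benzylamine on the shared core

The source may report more compounds than this note shows. Statements on the series, on what has been measured and on what is new or still open speak of the compounds shown alone.

Compound 3 `Nc1cc(N)c2nc(-c3ccccc3)c(NCc3ccc(F)cc3)nc2c1` gives 2040 nM in a functional assay on UACC-257 cells (Homo sapiens) for inhibition, read by sulforhodamine B assay, with a stated time of 48 h (on this read-out higher numbers stand for weaker inhibition of growth and lower numbers for stronger inhibition of growth), the lowest of the three numbers measured. Compound 1 `Nc1cc(N)c2nc(-c3ccccc3)c(NCc3ccc(Cl)c(Cl)c3)nc2c1` gives 4570 nM in this assay, and compound 2 `COc1ccc(CNc2nc3cc(N)cc(N)c3nc2-c2ccccc2)cc1OC` gives 12900 nM. The measured steps are a 2.2-fold lower number from compound 1 to compound 3 (0.35 log units; beyond the scatter) and a 6.3-fold lower number from compound 2 to compound 3 (0.80 log units; beyond the scatter) together with a 2.8-fold higher number from compound 1 to compound 2 (0.45 log units; beyond the scatter). Compound 4 `Nc1cc(N)c2nc(-c3ccccc3)c(Oc3ccc(F)cc3)nc2c1` differs from compound 3 in one place: 4-fluorophenoxy in place of (4-fluorobenzyl)amino on an aromatic carbon. All three measured steps exchange only the aryl ring carried by the benzyl group and keep the (4-fluorobenzyl)amino linkage; none replaces that linkage by a phenoxy group, so none of them bears directly on the present change, and the data give no guide to its size. The change removes the single hydrogen-bond donor and one heavy atom from this part of the molecule. Within the data shown here, with no precedent, a modest step to a higher number is expected for compound 4, namely a 2.0-fold higher number from compound 3 to compound 4 (0.29 log units; within the scatter). Compound 4 is therefore estimated at 4000 nM in this assay, with a wide range from 1200 nM to 15000 nM.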

Compound 4, concentration for 50% growth inhibition: 23400 nM
Compound 4: middle estimate off by 5.9-fold (0.77 log units), on the low side; measured number outside the range, above it.
By their numbers in this assay, from the lowest: compound 3; then compound 1; then compounds 2 and 4 (each within the scatter of the next).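

Among these compounds, exchanging (4-fluorobenzyl)amino for 4-fluorophenoxy on this aromatic carbon gives an 11-fold higher number from compound 3 to compound 4 (1.06 log units; beyond the scatter) in this assay, so growth inhibition here depends on the linkage as well as on the aryl ring, the only part varied among the earlier compounds. A group of 9 heavy atoms with 1 hydrogen-bond donor gives way to one of 8 heavy atoms with 0 hydrogen-bond donors, and this single step cannot separate these differences from each other. No measurement shown explains the loss of growth inhibition.

On these data alone, what remains open is whether a 4-fluorobenzyloxy group, which has an oxygen in the linkage but keeps the benzyl carbon, would behave like compound 3 or like compound 4. An N-methyl-(4-fluorobenzyl)amino group would likewise test the amine hydrogen while keeping the nitrogen in place.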